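The source may hold more compounds than are shown below. What is called first, only, known or untested is meant among the compounds shown, and "the series" means these compounds.

Of the compounds shown here, three sharing one core have been tested in an ADME assay on L02 cells (Homo sapiens) for cytotoxicity, read by MTT assay; a higher number here means a weaker inhibitor, a lower number a stronger inhibitor. Compound 1 `CCCCC(=O)Oc1cc(/C=C/C(=O)c2ccc(OC)c3c2OC(C)(C)C=C3)ccc1OC` gives > 10000 nM, which is a limit of the assay and not a number. Compound 2 `COc1ccc(/C=C/C(=O)c2ccc(OC)c3c2OC(C)(C)C=C3)cc1OC(=O)C(C)C` gives > 10000 nM, which is also a limit. Among the compounds with values here, compound 3 `COc1ccc(/C=C/C(=O)c2ccc(OC)c3c2OC(C)(C)C=C3)cc1OC(=O)c1ccc(Br)cc1` gives 8400 nM, the only actual number of the three.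

Compound 4 `COc1ccc(/C=C/C(=O)Oc2cc(/C=C/C(=O)c3ccc(OC)c4c3OC(C)(C)C=C4)ccc2OC)cc1` differs from compound 3 by one swap, 2-(4-methoxyphenyl)ethenyl in place of 4-bromophenyl on a carbonyl carbon. The measured steps at this same place are few and give little to go on. They are an at least 1.1-fold lower number from compound 1 to compound 3 (0.07 log units; that floor lies within the scatter), an at least 1.1-fold lower number from compound 2 to compound 3 (0.07 log units; that floor lies within the scatter) and a step that the two limits leave unreadable from compound 1 to compound 2.

The entering group keeps one six-membered aromatic ring of carbon only, as the leaving group does, so compound 3 at 8400 nM is the closest guide. The expected result is no change beyond the scatter, with an estimated 1.1-fold higher number from compound 3 to compound 4 (0.03 log units; within the scatter). For compound 4 the estimated value is 9000 nM, with an expected range from 4500 nM to 16000 nM. A reading that gives only a limit would be no surprise.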

Compound 4, half-maximal inhibitory concentration: 18000 nM
For compound 4 the middle estimate is 2.0-fold (0.30 log units) below the measured one; the whole stated range lies below it.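

In this assay, within the data shown here, placing 2-(4-methoxyphenyl)ethenyl instead of 4-bromophenyl on the carbonyl carbon gives a 2.1-fold higher number from compound 3 to compound 4 (0.33 log units; beyond the scatter), the first step at this position that can be read as lying beyond the scatter. Both groups keep one six-membered aromatic ring of carbon only, so sharing that ring does not keep the number the same. The steps to compound 4 from compound 1 and from compound 2 cannot be read, because those two compounds give a limit and not a number: the limit of > 10000 nM in this assay, at which 2 of the 4 values shown sit.

The entering group brings a double bond and a methoxy group together, so the compounds shown leave open which of the two goes with the step. As far as these compounds go, how a group carrying an amine or a carboxylic acid would read at this place also remains open.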